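A few compounds are considered here, and "the series" means these few. Any claim that something is new, unique, unknown or untested is made for them only; others in the source may bear on it.

Measured in a functional assay on CHO cells for agonist activity at Melanocyte-stimulating hormone receptor (Homo sapiens), read by a luciferase reporter, with a stated time of 4 h; on this read-out lower numbers stand for an effect already at smaller amounts and higher numbers for an effect only at larger amounts of compound:
compound 1 `COc1ccc(N(C(=O)CN2C=CN(c3cccnc3)C(=O)C(Cc3n[nH]c4cc(F)ccc34)C2=O)C(C)C)cc1` — 12.6 nM
compound 3 `COc1ccc(N(C(=O)CN2C=CN(c3cccnc3)C(=O)C(Cc3n[nH]c4ccccc34)C2=O)C(C)C)cc1` — 178 nM
compound 2 `COc1ccc(N(C(=O)CN2C=CN(C3CCCCC3)C(=O)C(Cc3ccccc3)C2=O)C(C)C)cc1` — 31600 nM; > 30000 nM (2 entries); compound 2 has several entries in this assay, as shown by the several entries of compound 2 in this assay, 31600 nM; > 30000 nM (2 entries).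

Compound 1 holds the lowest of the two numbers in this assay. Its nearest neighbour is compound 3, reached by a 14-fold higher number from compound 1 to compound 3 (1.15 log units; beyond the scatter) through hydrogen in place of fluoro on an aromatic carbon.

Compound 4 `COc1ccc(N(C(=O)CN2C=CN(c3ccccc3)C(=O)C(Cc3n[nH]c4cc(F)ccc34)C2=O)C(C)C)cc1` differs from compound 1 by phenyl in place of pyridin-3-yl on an amide-type nitrogen in a ring. Among the measured compounds shown here, no measured step exchanges these two rings: the step from compound 1 to compound 3 concerns the fluoro, and compound 2 differs in two places. The change is therefore expected to give only a small step, a 1.6-fold higher number from compound 1 to compound 4 (0.20 log units; within the scatter), within or little beyond the scatter. Compound 4 is estimated at 20 nM, in the range 5 nM to 80 nM.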

Compound 4, half-maximal effective concentration: 1.59 nM
Estimate against measurement, compound 4: 13-fold (1.10 log units) above; measured number outside the range, below it.
By their numbers in this assay, from the lowest: compound 4; then compound 1; then compound 3.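

In this assay, the aromatic ring on the amide-type nitrogen proves to be a position that moves the number: a 7.9-fold lower number from compound 1 to compound 4 (0.90 log units; beyond the scatter), with phenyl in place of pyridin-3-yl. Among the compounds shown here, the only earlier single-place step concerned the fluoro, so this pair gives the first reading at this position, and it shows that the ring nitrogen of pyridin-3-yl is not required for a low number. Nothing measured here gives a reason for this step. Still open, as far as these compounds go, is whether a chloro group or an amine on the phenyl keeps this low number, and whether the fluoro step carries over to the phenyl compounds.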